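This account rests on a few compounds, and the source may have more. Where it says the series, first, only, none or still open, it means among the compounds named here.

Measured compounds:
compound 1, `N#CC1=C(N)Oc2c(c3nc4ccccc4nc3c3ccccc23)C12C(=O)N(Cc1cnnn1-c1ccc(S(N)(=O)=O)cc1)c1ccccc12`, 31200 nM
compound 2, `N#CC1=C(N)Oc2c(N)cc3nc4ccccc4nc3c2C12C(=O)N(Cc1cnnn1-c1cccc(C(F)(F)F)c1)c1ccccc12`, 18900 nM

Going by the values given here, the two measured compounds share a common core but differ from each other in several places at once, so no single step between them can be isolated. In a functional assay on HCT-116 cells (Homo sapiens) for antiproliferative activity, read by MTT assay, with a stated time of 48 h (on this read-out lower numbers stand for stronger inhibition and higher numbers for weaker inhibition), compound 1 gives 31200 nM, and compound 2 gives 18900 nM. Compound 2 holds the lower of the two numbers, yet the gap to compound 1 lies within the usual scatter of such measurements, so the two values cannot be told apart.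

Compound 3, `Cc1cc(C)cc(-n2nncc2CN2C(=O)C3(C(C#N)=C(N)Oc4c(N)cc5nc6ccccc6nc5c43)c3ccccc32)c1`, remains to be measured in this assay. It differs from compound 2 in one place: 3,5-dimethylphenyl in place of 3-(trifluoromethyl)phenyl on an aromatic nitrogen. Among the compounds with values here, no measured pair shows what this kind of change does on the shared core, so the expectation rests on the level of compound 2 alone. The step of a 1.1-fold higher number from compound 2 to compound 3 (0.02 log units; within the scatter) is expected to stay within the scatter, with no clear direction. The estimate for compound 3 in this assay is 20000 nM, with a range from 8000 nM to 50000 nM.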

Compound 3, half-maximal inhibitory concentration: > 50000 nM
Compound 3: a limit, no number (the forecaster's own chance of this, stated with the estimate: 10%); at least 2.5-fold (0.39 log units) between middle value and limit.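

Among the compounds shown, this is the only step that changes a single place, and it shows that the group on the aromatic nitrogen of the five-membered ring matters in this assay. Going by these compounds alone, putting 3,5-dimethylphenyl in place of 3-(trifluoromethyl)phenyl there gives an at least 2.6-fold higher number from compound 2 to compound 3 (0.42 log units; beyond the scatter), a shift beyond the scatter that the earlier compounds could not reveal. Compound 3 gives > 50000 nM, which is a limit and not a number, so the step has only a lower bound: the limit of > 50000 nM in this assay, at which 1 of the 3 values shown sits.

The compounds shown do not separate the part played by the two methyl groups from the part played by the lost trifluoromethyl group. On these data alone, whether a plain phenyl, a benzyl or a pyridine ring at this position would stay close to compound 2 also remains open.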